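A few compounds are considered here, and "the series" means these few. Any claim that something is new, unique, unknown or untested is made for them only; others in the source may bear on it.

Going by the values given here, in a functional assay on MDA-MB-468 cells (Homo sapiens) for antiproliferative activity, read by sulforhodamine B assay, with a stated time of 4 days (a lower number here means a stronger inhibitor of growth, a higher number a weaker inhibitor of growth), two compounds have numbers so far. Compound 1 (`COc1cc(Cl)c(-c2nc(SCC(=O)NC3CC3)nc3[nH]cc(C#N)c23)cc1OC`) gives 62 nM. Compound 2 (`COc1cc(Cl)c(-c2nc(SCC(=O)NC(C)(C)C)nc3[nH]cc(C#N)c23)cc1O`) gives 152 nM, the higher of the two numbers and beyond the scatter from compound 1. Compound 3 (`COc1cc(Cl)c(-c2nc(SCC(=O)NC(C)(C)C)nc3[nH]cc(C#N)c23)cc1OC`) differs from compound 2 by methyl in place of hydrogen on an oxygen on an aromatic ring, that is, hydroxy to methoxy. Among the compounds with values here, no measured pair isolates this change. Compound 1 carries the methoxy, with a different amide group, and gives 62 nM, so a modest move to a lower number in this assay is expected, near the edge of the scatter. The estimated change is a 2.0-fold lower number from compound 2 to compound 3 (0.31 log units; beyond the scatter). For compound 3 the expected value is 75 nM, within an estimated range of 30 nM to 190 nM.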

Compound 3, concentration for 50% growth inhibition: 84 nM
Compound 3: middle estimate off by 1.1-fold (0.05 log units), on the low side; measured number inside the range.
By their numbers in this assay, from the lowest: compounds 1, 3 and 2 (each within the scatter of the next, the first and the last beyond it).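

In this assay, methyl in place of hydrogen on the oxygen, with the tert-butyl amide held fixed, gives a 1.8-fold lower number from compound 2 to compound 3 (0.26 log units; within the scatter), so hydroxy and methoxy cannot be told apart at this position. With the methoxy held fixed, tert-butyl in place of cyclopropyl on the amide-type nitrogen gives a 1.4-fold higher number from compound 1 to compound 3 (0.13 log units; within the scatter), so these two amide groups cannot be told apart either. No measurement here bears on the reason for these numbers.

Still open, going by these compounds, is whether an ethoxy group or a longer chain ending in an amine on that oxygen would stay in this range. The same question holds for a carboxylic acid on the amide-type nitrogen.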